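A few compounds are considered here, and "the series" means these few. Any claim that something is new, unique, unknown or untested is made for them only; others in the source may bear on it.

Compound 1 `C=C1C[C@]23C[C@@]1(O)CC[C@H]2c1ccc(O)c(C)c1[C@@H]3Cn1cc(-c2ccc(C(F)(F)F)cc2)nn1`: in a functional assay on HL-60 cells (Homo sapiens) for cytotoxicity, read by MTT assay, with a stated time of 4 days (a lower number here means a stronger inhibitor, a higher number a weaker inhibitor), compound 1 gives 8950 nM. Compound 2 `C=C1C[C@]23C[C@@]1(O)CC[C@H]2c1cc(Br)c(O)c(C)c1[C@@H]3Cn1cc(-c2ccccc2)nn1`: in this assay compound 2 gives > 20000 nM, which is a limit of the assay rather than a number.

Compound 2 thus stands at the limit of > 20000 nM in this assay, at which 1 of the 2 values shown sits, so its potency is not pinned down. Compound 3 `C=C1C[C@]23C[C@@]1(O)CC[C@H]2c1cc(Br)c(O)c(C)c1[C@@H]3Cn1cc(-c2ccc(C(F)(F)F)cc2)nn1` is compound 2 with trifluoromethyl in place of hydrogen on an aromatic carbon. For the measured compounds named here, no measured pair shows what this change does on its own; since compound 1 carries the same trifluoromethyl-bearing ring and gives 8950 nM, only a modest step, of uncertain direction, is expected in this assay. Compound 3 is expected at 15000 nM, within 5000 nM to 40000 nM, a step of an at least 1.3-fold lower number from compound 2 to compound 3 (0.12 log units; that floor lies within the scatter).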

Compound 3, half-maximal inhibitory concentration: 7380 nM
The estimate for compound 3 lay 2.0-fold (0.31 log units) above the measured number, within the range that was stated.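

With bromo on the core, the change from phenyl to 4-(trifluoromethyl)phenyl gives, in this assay, an at least 2.7-fold lower number from compound 2 to compound 3 (0.43 log units; beyond the scatter). Compound 2 stands at a limit and not a number: the limit of > 20000 nM in this assay, at which 1 of the 3 values shown sits. With the 4-(trifluoromethyl)phenyl group kept, bromo in place of hydrogen on an aromatic carbon gives a 1.2-fold lower number from compound 1 to compound 3 (0.08 log units; within the scatter), so this bromo makes no readable difference here.

The compounds shown leave open whether an amine or a carboxylic acid on that same ring carbon would act like trifluoromethyl. They also leave open whether the phenyl change gives a similar step without the bromo.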